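Swapping fluoro for chloro in a bicyclic amide pair

The compounds below may be only part of what the source reports. "The series", "measured", "known", "first", "only" and "open" are said of these compounds alone.

Measured compounds:
compound 1, `O=C(N1CCC(F)CC1)N1CC(c2nc(-c3cccc(Cl)c3)no2)C1`: 990 nM
compound 2, `O=C(N1CCCCC1)N1CC(c2nc(-c3cccc(Cl)c3)no2)C1`: 370 nM
compound 3, `O=C([C@@H]1CC2CCC1C2)N1CC(c2nc(-c3cccc(F)c3)no2)C1`: 100 nM

All three numbers come from an assay on HEK293 cells for positive allosteric modulation of metabotropic glutamate receptor 5 (Homo sapiens), read by FLIPR; on this read-out higher numbers stand for an effect only at larger amounts of compound and lower numbers for an effect already at smaller amounts. Compound 3 stands at the lowest number of the three, with compound 2 the nearest and compound 1 the furthest, both gaps beyond the scatter. Compound 3 and compound 2, however, differ in two places at once: the amide part and the halogen on the phenyl ring, so the halogen's share of that gap cannot be read off.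

Compound 4, `O=C([C@@H]1CC2CCC1C2)N1CC(c2nc(-c3cccc(Cl)c3)no2)C1`, keeps the bicyclic amide of compound 3 and carries chloro in place of fluoro on an aromatic carbon. Going by the values given here, the single measured step, a 2.7-fold lower number from compound 1 to compound 2 (0.43 log units; beyond the scatter), concerns a fluoro on a saturated ring carbon, not a halogen on the aromatic ring, so it does not bear on this change. Compounds 1 and 2 show only that the chlorophenyl is tolerated with other amides.

Among the compounds with values here, with no matching step in hand, a small change in this assay is expected, in either direction, likely within the scatter; the step from compound 3 to compound 4 is estimated at a 1.3-fold lower number from compound 3 to compound 4 (0.10 log units; within the scatter). Compound 4 is therefore expected to give about 80 nM, with a range from 30 nM to 250 nM.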

Compound 4, half-maximal effective concentration: 98 nM
Compound 4: middle estimate off by 1.2-fold (0.09 log units), on the low side; the measured number falls inside the stated range.
By their numbers in this assay, from the lowest: compounds 4 and 3 (each within the scatter of the next); then compound 2; then compound 1.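

In this assay, going from 3-fluorophenyl to 3-chlorophenyl gives a 1.0-fold lower number from compound 3 to compound 4 (0.01 log units; within the scatter), so with the bicyclic amide this aromatic carbon takes either halogen without a difference that can be told from the scatter. With chloro now held constant, the amide part can also be read on its own: replacing the six-membered ring with one hetero atom by the bicyclic carbon group gives a 3.8-fold lower number from compound 2 to compound 4 (0.58 log units; beyond the scatter), and the same replacement against the fluoro-bearing ring of compound 1 gives a 10-fold lower number from compound 1 to compound 4 (1.00 log units; beyond the scatter), both beyond the scatter, so among these compounds the amide part marks the measured differences, while the swap of these two halogens does not. Nothing measured here explains why the two halogens read alike or why the amide part matters.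

The compounds shown leave open whether a nitrile, a methoxy group or a plain hydrogen at this aromatic carbon would also read like fluoro and chloro. They also leave open whether fluoro and chloro read alike with the amide parts of compound 1 and compound 2, since the comparison rests on the bicyclic amide alone.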